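A few compounds are considered here, and "the series" means these few. Any claim that something is new, unique, unknown or untested is made for them only; others in the source may bear on it.

In a functional assay on P388 cells (Mus musculus) for cytotoxicity, read by MTT assay, with a stated time of 72 h (on this read-out higher numbers stand for weaker inhibition and lower numbers for stronger inhibition), compound 1 `Cc1c(/N=C/c2ccccc2Cl)c(=O)n(-c2ccccc2)n1C` gives 324000000 nM, and compound 2 `Cc1c(/N=C/c2ccc(Cl)cc2Cl)c(=O)n(-c2ccccc2)n1C` gives 363000000 nM. Compound 2 holds the highest of the two numbers seen so far, though its nearest neighbour is compound 1, and the step of a 1.1-fold higher number from compound 1 to compound 2 (0.05 log units; within the scatter) sits within the usual scatter of this assay, so neither compound can be called weaker or stronger than the other.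

The next compound, compound 3 `Cc1c(/N=C/c2ccc(O)cc2)c(=O)n(-c2ccccc2)n1C`, differs from compound 2 in one place: 4-hydroxyphenyl in place of 2,4-dichlorophenyl on a carbon with a double bond to nitrogen. Within the data shown here, the only measured step that bears on this change is the one from compound 1 to compound 2, which also swapped a substituent on the same aromatic ring and produced no movement beyond the scatter. Among the measured compounds shown here, no measured pair shows what a hydroxyphenyl group does in this position, so the expectation rests on that single step alone. On that basis compound 3 is expected to show a step of about a 1.1-fold lower number from compound 2 to compound 3 (0.03 log units; within the scatter) in this assay, that is, no change beyond the scatter. Compound 3 is therefore estimated to give roughly 340000000 nM, with a range from 110000000 nM to 1000000000 nM.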

Compound 3, half-maximal inhibitory concentration: 537000000 nM
Compound 3: middle estimate off by 1.6-fold (0.20 log units), on the low side, and the stated range covers the measured number.
By their numbers in this assay, from the lowest: compounds 1, 2 and 3 (each within the scatter of the next).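

Across the wider swap on the carbon with a double bond to nitrogen, this assay still separates none of the compounds: the printed steps are (a 1.5-fold higher number from compound 2 to compound 3 (0.17 log units; within the scatter)) and (a 1.7-fold higher number from compound 1 to compound 3 (0.22 log units; within the scatter)), and both lie within the scatter. The earlier step showed only that adding one chloro to the aromatic ring left the number within the scatter, whereas these steps replace the whole group: 2,4-dichlorophenyl or 2-chlorophenyl leaves, 4-hydroxyphenyl enters, and the swap from 2,4-dichlorophenyl removes both chlorine atoms and brings in one hydrogen-bond donor and one hydrogen-bond acceptor where there were none. So among compounds 1, 2 and 3, none of these aromatic groups can be told from the others in this assay, and nothing measured here offers an explanation for that.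

Still open, from the compounds shown here alone, is whether an amine, a carboxylic acid or a methoxy group on this aromatic ring, or a longer alkyl chain in place of the ring, would move the number beyond the scatter. The shared core also stays the same throughout, so these compounds say nothing about changes anywhere else on it.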